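Swapping the aryl group on a piperazine-bearing core

The source may hold more compounds than are shown below. What is called first, only, known or untested is meant among the compounds shown, and "the series" means these compounds.

Compound 1 `Fc1ccc(N2CCN(Cn3nc(-c4ccc5c(c4)OCCO5)oc3=S)CC2)cc1` gives > 50000 nM in a functional assay on BGC-823 cells (Homo sapiens) for antiproliferative activity, read by MTT assay, with a stated time of 48 h; a higher number here means a weaker inhibitor, a lower number a stronger inhibitor.
Compound 2 `COc1cccc(N2CCN(Cn3nc(-c4ccc5c(c4)OCCO5)oc3=S)CC2)c1` gives > 50000 nM.
Compound 3 `S=c1oc(-c2ccc3c(c2)OCCO3)nn1CN1CCN(c2ccccc2Cl)CC1` gives > 50000 nM.

The value of compound 1 is a limit of the assay, not a number. The value of compound 2 is likewise a limit. The value of compound 3 is also a limit, so compound 3 stands at the limit of > 50000 nM in this assay, at which 3 of the 3 values shown sit, alongside the other two. The change to compound 4 `O=[N+]([O-])c1ccc(N2CCN(Cn3nc(-c4ccc5c(c4)OCCO5)oc3=S)CC2)cc1` is 4-nitrophenyl in place of 2-chlorophenyl on an amine nitrogen in a ring. The measured steps a step that the two limits leave unreadable from compound 1 to compound 2, a step that the two limits leave unreadable from compound 1 to compound 3 and a step that the two limits leave unreadable from compound 2 to compound 3 bear on this change, yet their sizes are not readable; both ends of each sit at a limit. No step beyond the scatter can therefore be expected in either direction, and the expected step of a number no higher from compound 3 to compound 4 (the limit leaves the size open) is set at none, with a wide range. Compound 4 is estimated at 50000 nM, between 5000 nM and 200000 nM.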

Compound 4, half-maximal inhibitory concentration: > 50000 nM
Compound 4: only a limit was reported (the forecaster's own chance of this, stated with the estimate: 80%); the middle value sits exactly at the limit.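

No step among compound 1, compound 2, compound 3 and compound 4 can be read, because each value is a limit of the assay, not a number: the limit of > 50000 nM in this assay, at which 4 of the 4 values shown sit.

The compounds shown leave open whether these swapped groups differ in activity at all.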